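The source may hold more compounds than are shown below. What is called first, only, known or untested is meant among the compounds shown, and "the series" means these compounds.

Working notes on the series.

Compound 1 `Cc1ccc(-c2nn(-c3ccc(Br)cc3)c(/N=C/N(C)C)c2C=O)cc1` serves as the reference; in a functional assay on NPC-TW01 cells (Homo sapiens) for inhibition, read by MTT assay, with a stated time of 72 h (on this read-out higher numbers stand for weaker inhibition of growth and lower numbers for stronger inhibition of growth), compound 1 gives 6000 nM. Compound 2 `CN(C)/C=N/c1c(C=O)c(-c2ccc(Cl)cc2)nn1-c1ccc(Br)cc1` carries a single change against it, (chloro in place of methyl on an aromatic carbon). In this assay compound 2 reaches only the limit of the measurement, > 100000 nM. As far as these compounds go, the step of an at least 16-fold higher number from compound 1 to compound 2 (1.22 log units; beyond the scatter) is thus known only as a lower bound, and its full size remains open because the limit of > 100000 nM in this assay, at which 2 of the 3 values shown sit, holds the second of the two values.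

Compound 3 `Cc1ccc(-c2nn(-c3cccc(Cl)c3)c(N)c2C=O)cc1` has a core that differs from that of compound 1; the difference between the two cores is not broken down here. In this assay compound 3 sits at the limit of the measurement, > 100000 nM. Within the data shown here, compound 4 `Nc1c(C=O)c(-c2ccc(Cl)cc2)nn1-c1cccc(Cl)c1` has not been measured; it differs from compound 3 by chloro in place of methyl on an aromatic carbon, which is the same change, at the same kind of place, as the one made from compound 1 to compound 2.

The expectation for compound 4 rests on two points: compound 3 already gives no number but a limit, and the same change produced an at least 16-fold higher number from compound 1 to compound 2 (1.22 log units; beyond the scatter), a move toward weaker inhibition of growth. The step from compound 3 to compound 4 is therefore expected to be a step that the limit leaves unreadable from compound 3 to compound 4, in the same direction or flat. Compound 4 is expected to give about 250000 nM, between 60000 nM and 1000000 nM, and most probably this assay will again report only a limit for compound 4 rather than a number.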

Compound 4, concentration for 50% growth inhibition: > 100000 nM
Compound 4: only a limit was reported; the forecaster's own chance of this, stated with the estimate: 85%; the middle value does not contradict the limit.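

In this assay compound 4 gives only a limit, > 100000 nM, and no new step can be read between compound 3 and compound 4, since compound 3 also stands at a limit: the limit of > 100000 nM in this assay, at which 3 of the 4 values shown sit.

The compounds shown leave open whether compound 3 and compound 4 differ at all in inhibition of growth, and how large the change from 4-methylphenyl to 4-chlorophenyl really is in either pair.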